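Series notes: one hydroxy removed from compound 2

The source may report more compounds than this note shows. Statements on the series, on what has been measured and on what is new or still open speak of the compounds shown alone.

Measured in an assay on cells for inhibition of Amine oxidase [flavin-containing] B (Homo sapiens), read by fluorescence, with stated times of 10 min and 20 min, tested at 25 uM; on this read-out higher numbers stand for more inhibition at the one concentration tested (going by the name of the read-out) and lower numbers for less inhibition:
compound 1 `CC(C)=CCc1c(O)cc(O)c(C=O)c1C` gives 36.3%
compound 2 `CC(C)=CCc1c(C)cc(O)c(O)c1O` gives 32.7%

Compound 2 and compound 1 lie within the usual scatter of each other, so the two numbers do not separate them. Compound 3 `CC(C)=CCc1c(C)cc(O)cc1O` differs from compound 2 in one place: hydrogen in place of hydroxy on an aromatic carbon. Going by the values given here, no step between measured compounds is at hand to calibrate this change, so the expected step in this assay is small, a slight fall or none beyond the scatter. For compound 3 the estimate is 28% (12% to 44%), which is expected to mean a step of a number 4.7 percentage points lower from compound 2 to compound 3 (within the scatter).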

Compound 3, a percentage reported as inhibition, at one concentration (the size of the read-out at that concentration, not a potency): 4.2%
Compound 3: middle estimate off by 23.8 percentage points, on the high side; measured number below the stated range.
By their numbers in this assay, from the lowest: compound 3; then compounds 2 and 1 (each within the scatter of the next).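

The hydroxy ortho to two hydroxy groups matters in this assay: its replacement by hydrogen gives a number 28.5 percentage points lower from compound 2 to compound 3 (beyond the scatter), a drop that the similar values of compound 1 and compound 2 gave no sign of. Hydrogen in place of formyl, on a different aromatic carbon, gives a number 32.1 percentage points lower from compound 1 to compound 3 (beyond the scatter), so either group added to compound 3 goes with higher inhibition. No measurement bears on the cause of these steps.

From the compounds shown here alone, whether a methoxy or an amine at the hydroxy position would keep the inhibition remains open. Also open, going by these compounds, is whether a carboxylic acid could stand in for the formyl.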